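Oxygen-to-sulfur swap at the ester of compound 1

The source may report more compounds than this note shows. Statements on the series, on what has been measured and on what is new or still open speak of the compounds shown alone.

Going by the values given here, compound 1 `CC(/C=C/CC(C)CCCC(C)C)=C\C(=O)OC(C)C` sits highest of the three numbers so far in a physicochemical assay for lipophilicity (on this read-out lower numbers stand for lower lipophilicity and higher numbers for higher lipophilicity), where compound 1 gives 7.15. Compound 2 `CC(/C=C/CC(C)CCCC(C)(C)O)=C\C(=O)OC(C)C` gives 5.06 in this assay and lies a number 2.09 log units lower from compound 1 to compound 2 (beyond the scatter). Compound 3 `CSC(C)(C)CCCC(C)C/C=C/C(C)=C/C(=O)OC(C)C` gives 6.77 and lies a number 0.38 log units lower from compound 1 to compound 3 (beyond the scatter); compared with compound 2 it lies a number 1.71 log units higher from compound 2 to compound 3 (beyond the scatter).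

Compound 4 `CC(/C=C/CC(C)CCCC(C)C)=C\C(=O)SC(C)C` is not yet measured. It differs from compound 1 as follows: isopropylsulfanyl in place of isopropoxy on a carbonyl carbon.

Among the compounds with values here, none of the measured steps exchanges oxygen for sulfur on a carbonyl carbon. The nearest guide is the step between compound 2 and compound 3, where sulfur enters in place of oxygen on a saturated chain carbon and this assay rises by a number 1.71 log units higher from compound 2 to compound 3 (beyond the scatter); that pair, however, also trades a hydrogen-bond donor for a methyl group, so its full size should not be carried over. The step from compound 1 to compound 3, a number 0.38 log units lower from compound 1 to compound 3 (beyond the scatter), shows that sulfur alone moves this assay only modestly.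

A rise beyond the scatter is therefore expected for compound 4, smaller than the step from compound 2 to compound 3: the expected change is a number 0.60 log units higher from compound 1 to compound 4 (beyond the scatter). Compound 4 is estimated at 7.75 in this assay, with a range from 7.3 to 8.25.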

Compound 4, partition coefficient: 8.39
The estimate for compound 4 lay 0.64 log units below the measured number, outside the stated range (above it).
By their numbers in this assay, from the lowest: compound 2; then compound 3; then compound 1; then compound 4.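

Working notes on the carbonyl position: in this assay, isopropylsulfanyl in place of isopropoxy on a carbonyl carbon gives a number 1.24 log units higher from compound 1 to compound 4 (beyond the scatter) and places compound 4 highest of the four numbers, so this position responds strongly to an exchange of oxygen for sulfur. Going by these compounds alone, the earlier compounds held no change at this carbon; their steps all lay on a saturated chain carbon, and the one exchange of oxygen for sulfur among them, a number 1.71 log units higher from compound 2 to compound 3 (beyond the scatter) in the same assay, also replaced hydroxy with methylsulfanyl, whereas here the isopropyl group stays and the computed heavy-atom, donor and acceptor counts stay level. Nothing shown gives a measured reason for the size of this step, so it stands as an observation only.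

The compounds shown leave open whether the same exchange at the carbonyl carbon would give a step of similar size on the hydroxy-bearing chain of compound 2 or the methylsulfanyl-bearing chain of compound 3. Also open, going by these compounds, is how the read-out would respond to isopropylamino, a carboxylic acid or a longer alkylsulfanyl chain on that carbonyl carbon.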